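The source may hold more compounds than are shown below. What is called first, only, known or untested is meant among the compounds shown, and "the series" means these compounds.

Measured in a functional assay on MCF7 cells (Homo sapiens) for cytotoxicity, read by neutral red uptake, with a stated time of 3 days; on this read-out higher numbers stand for weaker inhibition and lower numbers for stronger inhibition:
compound 1 `Nc1ccc(-c2cc(=O)c3c(N)c(F)c(Br)c(F)c3o2)cc1F`: 160 nM
compound 2 `CCCCCC(=O)OCc1c(F)c(N)c2c(=O)cc(-c3ccc(N)c(F)c3)oc2c1F`: 160 nM
compound 3 `COCc1c(F)c(N)c2c(=O)cc(-c3ccc(N)c(F)c3)oc2c1F`: 46 nM

Compound 1 sits level with compound 2, the two together giving the highest numbers of the three; the step of no change at the digits printed from compound 1 to compound 2 (within the scatter) is flat, while compound 3 is furthest away, a 3.5-fold lower number from compound 1 to compound 3 (0.54 log units; beyond the scatter).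

Compound 4 `CN(C)Cc1c(F)c(N)c2c(=O)cc(-c3ccc(N)c(F)c3)oc2c1F` differs from compound 1 in one place: (dimethylamino)methyl in place of bromo on an aromatic carbon. Both measured steps from compound 1 act at this same aromatic carbon, each putting a substituted methyl group in place of bromo, and they gave at one extreme no change, no change at the digits printed from compound 1 to compound 2 (within the scatter), and at the other a modest lowering, a 3.5-fold lower number from compound 1 to compound 3 (0.54 log units; beyond the scatter). For (dimethylamino)methyl a small lowering within that span is expected, a 1.8-fold lower number from compound 1 to compound 4 (0.25 log units; within the scatter). Compound 4 is estimated at 90 nM, with a range of 30 nM to 300 nM.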

Compound 4, half-maximal inhibitory concentration: 72 nM
Compound 4: the middle estimate sits 1.3-fold (0.10 log units) above what was measured, within the range that was stated.
By their numbers in this assay, from the lowest: compounds 3 and 4 (each within the scatter of the next); then compounds 1 and 2 (each within the scatter of the next).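

In this assay (dimethylamino)methyl in place of bromo gives a 2.2-fold lower number from compound 1 to compound 4 (0.35 log units; beyond the scatter), so an amine-bearing methyl group, like methoxymethyl, moves beyond the scatter from bromo. At the saturated chain carbon, dimethylamino in place of methoxy gives a 1.6-fold higher number from compound 3 to compound 4 (0.19 log units; within the scatter), leaving these two groups unresolved, whereas dimethylamino in place of (pentylcarbonyl)oxy gives a 2.2-fold lower number from compound 2 to compound 4 (0.35 log units; beyond the scatter), and compound 2 alone stays level with the bromo compound. No available evidence bears on these differences. Open, going by these compounds, is how a primary amine, a morpholine or a carboxylic acid on this methyl carbon would compare. Also open, on these data alone, is how a plain hydroxymethyl group would read here.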